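The source may report more compounds than this note shows. Statements on the series, on what has been measured and on what is new or still open speak of the compounds shown alone.

Working notes on the step from compound 2 to compound 3.

Among the compounds with values here, in an ADME assay on microsomes from liver (Rattus norvegicus) for metabolic stability, read by LC-MS, tested at 1 uM (a lower number here means slower removal, a higher number faster removal of the compound), compound 2 `NC(=O)C1CCN(Cc2ccc([C@H]3CC[C@]4(CC3)OOC3(O4)C4CC5CC(C4)CC3C5)cc2)CC1` gives 25 mL.min-1.g-1, the only actual number so far. Compound 1 `NCCCOc1ccc([C@H]2CC[C@]3(CC2)OOC2(O3)C3CC4CC(C3)CC2C4)cc1` gives < 7 mL.min-1.g-1, which is a limit of the assay and not a number.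

Compound 3 `c1cc([C@H]2CC[C@]3(CC2)OOC2(O3)C3CC4CC(C3)CC2C4)ccc1OCCC1CCNCC1` is not yet measured. It differs from compound 2 as follows: 2-(piperidin-4-yl)ethoxy in place of (4-carbamoylpiperidin-1-yl)methyl on an aromatic carbon. In words, 2-(piperidin-4-yl)ethoxy stands in place of (4-carbamoylpiperidin-1-yl)methyl on an aromatic carbon.

Within the data shown here, the one measured step that bears on this is an at least 3.5-fold higher number from compound 1 to compound 2 (0.55 log units; beyond the scatter), which replaced 3-aminopropoxy with the same (4-carbamoylpiperidin-1-yl)methyl group. Compound 3 loses that group and returns to an alkoxy chain, as in compound 1, so part of an at least 3.5-fold higher number from compound 1 to compound 2 (0.55 log units; beyond the scatter) is expected to reverse in this assay. The expected change is a 2.1-fold lower number from compound 2 to compound 3 (0.32 log units; beyond the scatter), towards slower removal, with little evidence behind it. For compound 3 the estimate is 12 mL.min-1.g-1, with an expected range of 5 mL.min-1.g-1 to 30 mL.min-1.g-1.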

Compound 3, intrinsic clearance in microsomes: 9 mL.min-1.g-1
Compound 3: the middle estimate sits 1.3-fold (0.12 log units) above what was measured; the measured number falls inside the stated range.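

In this assay, within the data shown here, 2-(piperidin-4-yl)ethoxy in place of (4-carbamoylpiperidin-1-yl)methyl on this aromatic carbon, para to a large group, gives a 2.8-fold lower number from compound 2 to compound 3 (0.44 log units; beyond the scatter), the first step at this position read between two actual numbers. On the alkoxy chain, piperidin-4-yl in place of aminomethyl gives an at least 1.2-fold higher number from compound 1 to compound 3 (0.10 log units; that floor lies within the scatter), which fixes no order between these two chains. The value of compound 1 is a limit and not a number, so that step cannot tell how far the two chains lie apart: the limit of < 7 mL.min-1.g-1 in this assay, at which 1 of the 3 values shown sits.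

The step to compound 3 changes the link to the aromatic ring, the attachment of the piperidine and the carboxamide together, which leaves open which of them carries the difference. A plain piperidin-1-ylmethyl group, without the carboxamide, would separate the carboxamide from the rest.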